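A few compounds are considered here, and "the series" means these few. Any claim that something is new, unique, unknown or untested is made for them only; others in the source may bear on it.

Of the compounds shown here, three built on one shared core have been tested in a functional assay on the whole organism with Rattus norvegicus as the target; on this read-out higher numbers stand for an effect only at larger amounts of compound and lower numbers for an effect already at smaller amounts. Compound 1, `CCCc1c(OC)nc2nc(-c3noc(C)n3)cn2c1C`, gives 5 mg/kg in this assay. Compound 2, `C=CCc1c(OC)nc2nc(-c3noc(C)n3)cn2c1C`, differs from compound 1 by vinyl in place of ethyl on a saturated chain carbon bound to an aromatic carbon. In this assay compound 2 gives 10 mg/kg; the step of a 2.0-fold higher number from compound 1 to compound 2 (0.30 log units; within the scatter) is small. Compound 3, `CCCc1c(OC)nc2nc(-c3nnc(C)o3)cn2c1C`, differs from compound 1 in the core itself, as described by 5-methyl-1,3,4-oxadiazol-2-yl in place of 5-methyl-1,2,4-oxadiazol-3-yl on an aromatic carbon. In this assay compound 3 gives 10 mg/kg; the step of a 2.0-fold higher number from compound 1 to compound 3 (0.30 log units; within the scatter) is small as well. Going by the values given here, compound 2 and compound 3 stand level with each other at the digits reported, and no step between them is broken down here.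

Compound 4, `C=CCc1c(OC)nc2nc(-c3nnc(C)o3)cn2c1C`, has not yet been measured in this assay. It differs from compound 3 by vinyl in place of ethyl on a saturated chain carbon bound to an aromatic carbon, which is the same change that turns compound 1 into compound 2, made at the same place, but on the core of compound 3 rather than on the core of compound 1. Among the compounds with values here, with only one earlier example of this change to draw on, the step from compound 3 to compound 4 is expected to be a 2.0-fold higher number from compound 3 to compound 4 (0.30 log units; within the scatter), because the step of a 2.0-fold higher number from compound 1 to compound 2 (0.30 log units; within the scatter) was of that size and the core of compound 3 is assumed to respond alike. On that basis compound 4 is expected to give about 20 mg/kg in this assay, with an estimated range from 8 mg/kg to 50 mg/kg.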

Compound 4, minimum effective dose: 10 mg/kg
For compound 4 the middle estimate is 2.0-fold (0.30 log units) above the measured one, and the stated range covers the measured number.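

Carrying vinyl in place of ethyl onto the core of compound 3 gives, in this assay, no change at the digits printed from compound 3 to compound 4 (within the scatter), and exchanging one methyl-oxadiazole for the other with the allyl chain in place gives no change at the digits printed from compound 2 to compound 4 (within the scatter). Taken beside the earlier step, the chain change shows no difference between the two cores that rises above the ordinary spread of such measurements: the same change on two cores in this assay, a 2.0-fold higher number (0.30 log units; within the scatter) from compound 1 to compound 2 and no change at the digits printed (within the scatter) from compound 3 to compound 4, 2.0-fold (0.30 log units) apart, within the scatter of two such steps The same holds for the oxadiazole exchange, but with just two cores and steps this small, the result shows only that nothing separates the steps here, not that either change would carry over the same way to other cores in this series or that a real effect of a change would do so: the same change on two cores in this assay, a 2.0-fold higher number (0.30 log units; within the scatter) from compound 1 to compound 3 and no change at the digits printed (within the scatter) from compound 2 to compound 4, 2.0-fold (0.30 log units) apart, within the scatter of two such steps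

Going by these compounds, what a longer chain such as butyl, or a small ring such as cyclopropyl, would give in place of the propyl or allyl group remains open, and so does whether any group on that carbon can move the dose beyond the scatter. Also open, on these data alone, is how an amine or a carboxylic acid in place of the methyl on the oxadiazole would read out in this assay.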